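Trading bromo for 2,2,2-trifluoroethoxy on compound 2

The compounds below may be only part of what the source reports. "The series", "measured", "known", "first", "only" and "open" are said of these compounds alone.

Among the measured compounds shown here, in a functional assay on MDA-MB-231 cells (Homo sapiens) for cytotoxicity, read by MTT assay, with a stated time of 72 h (a lower number here means that less compound is needed, a higher number that more compound is needed for the effect), compound 1 `CCOC(=O)c1c(C)coc1-c1ccc2c(CC)cccc2c1OC` gives 3.9 ug/mL and compound 2 `CCc1cccc2c(OC)c(-c3occ(C)c3CBr)ccc12` gives 4.6 ug/mL, so compound 2 stands within the scatter of the only other measured compound. Compound 3 `CCc1cccc2c(OC)c(-c3occ(C)c3COCC(F)(F)F)ccc12` is still to be measured. It carries 2,2,2-trifluoroethoxy in place of bromo on a saturated chain carbon bound to an aromatic carbon. For the measured compounds named here, the one measured step bearing on this is a 1.2-fold higher number from compound 1 to compound 2 (0.07 log units; within the scatter), where bromomethyl took the place of ethoxycarbonyl. Going by the values given here, with only that small step as a guide, no shift beyond the scatter is expected, and the estimated step is a 1.1-fold higher number from compound 2 to compound 3 (0.04 log units; within the scatter). For compound 3 the expected value in this assay is 5 ug/mL, with an estimated range of 2.2 ug/mL to 12 ug/mL.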

Compound 3, concentration for half-maximal effect: 5.3 ug/mL
For compound 3 the middle estimate is 1.1-fold (0.03 log units) below the measured one; low and high end bracket the measured number.
By their numbers in this assay, from the lowest: compounds 1, 2 and 3 (each within the scatter of the next).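

In this assay, the saturated chain carbon bound to an aromatic carbon accepts 2,2,2-trifluoroethoxy in place of bromo with a 1.2-fold higher number from compound 2 to compound 3 (0.06 log units; within the scatter) as the whole effect, so the change from bromo adds no shift beyond the scatter. The wider change of ethoxycarbonyl to (2,2,2-trifluoroethoxy)methyl gives a 1.4-fold higher number from compound 1 to compound 3 (0.13 log units; within the scatter) and also stays within the scatter, leaving all three groups indistinguishable here. Nothing measured here offers an explanation for these numbers. From the compounds shown here alone, whether an amine, a carboxylic acid or a longer chain at this place would move the number beyond the scatter remains open.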